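Aryl ring change from compound 3 to compound 4

This account rests on a few compounds, and the source may have more. Where it says the series, first, only, none or still open, it means among the compounds named here.

Three compounds of the series have been run in an ADME assay on Vero cells (Chlorocebus sabaeus) for cytotoxicity, read by neutral red uptake, tested at 197 ug/mL; a lower number here means a stronger effect, a higher number a weaker effect of the compound at the concentration tested. Compound 1 `O=C1CSC(c2ccc([N+](=O)[O-])cc2)N1CCN1CCCCC1` gives 72% and compound 2 `O=C1CSC(c2ccc(F)cc2)N1CCN1CCCCC1` gives 73%; the step of a number 1 percentage points higher from compound 1 to compound 2 (within the scatter) lies within the scatter. Compound 3 `O=C1CSC(c2cccc(F)c2)N1CCN1CCCCC1` gives 84%, and the step of a number 11 percentage points higher from compound 2 to compound 3 (beyond the scatter) lies beyond the scatter. On the numbers shown, compound 3 stands highest of the three, with compound 2 nearest and compound 1 furthest, both gaps beyond the scatter.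

Compound 4 `O=C1CSC(c2ccc(Cl)cc2)N1CCN1CCCCC1` is not yet measured. The change from compound 3 is 4-chlorophenyl in place of 3-fluorophenyl on a saturated ring carbon. Among the measured compounds shown here, two measured steps bear on it. The step of a number 11 percentage points higher from compound 2 to compound 3 (beyond the scatter) shows that 4-fluorophenyl against 3-fluorophenyl made a modest difference beyond the scatter, and the step of a number 1 percentage points higher from compound 1 to compound 2 (within the scatter) shows that the identity of the group on the aromatic carbon, nitro against fluoro, made no difference beyond the scatter. Compound 4 carries 4-chlorophenyl, a ring substituted in the manner of compound 2 and compound 1 rather than compound 3, so the expected step is a modest fall, a number 10 percentage points lower from compound 3 to compound 4 (within the scatter), bringing compound 4 near compound 2. Compound 4 is therefore estimated at 74%, with a range from 62% to 86%.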

Compound 4, a percentage reported as activity, at one concentration (the size of the read-out at that concentration, not a potency): 68%
Compound 4: the middle estimate sits 6 percentage points above what was measured; the measured number falls inside the stated range.
By their numbers in this assay, from the lowest: compounds 4, 1 and 2 (each within the scatter of the next); then compound 3.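

In this assay, chloro in place of fluoro (a number 5 percentage points lower from compound 2 to compound 4 (within the scatter)) and chloro in place of nitro (a number 4 percentage points lower from compound 1 to compound 4 (within the scatter)) both stay within the scatter, so the three groups on the aromatic carbon in compound 1, compound 2 and compound 4 cannot be told apart in this read-out. Among the compounds shown here, the 3-fluorophenyl to 4-chlorophenyl change (a number 16 percentage points lower from compound 3 to compound 4 (beyond the scatter)) lies beyond the scatter, which leaves compound 3 as the only one of the four compounds separated from all the others, and it is also the only one carrying 3-fluorophenyl on the saturated ring carbon. No measurement at hand gives a reason for this separation.

On these data alone, with a single 3-fluorophenyl compound in the set, it remains open whether the separation goes with the placement of the group on the ring or is particular to fluoro at that placement. A 3-chlorophenyl or 3-nitrophenyl group on the same saturated ring carbon would address that question, and an unsubstituted phenyl group would show where the bare ring falls relative to compound 3 and compound 4.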